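Removing the anilide methyls in a dienone series

A few compounds are considered here, and "the series" means these few. Any claim that something is new, unique, unknown or untested is made for them only; others in the source may bear on it.

Measured so far:
compound 1 `Cc1cccc(C)c1NC(=O)/C=C/C(=O)N1C/C(=C\c2ccccc2)C(=O)/C(=C/c2ccccc2)C1`, 7400 nM;
compound 2 `O=C(/C=C/C(=O)N1C/C(=C\c2ccc([N+](=O)[O-])cc2)C(=O)/C(=C/c2ccc([N+](=O)[O-])cc2)C1)Nc1ccc(Cl)c(Cl)c1`, 380 nM;
compound 3 `O=C(/C=C/C(=O)N1C/C(=C\c2ccc([N+](=O)[O-])cc2)C(=O)/C(=C/c2ccc([N+](=O)[O-])cc2)C1)Nc1ccc(Cl)cc1`, 810 nM.

In a functional assay on CCRF-CEM cells (Homo sapiens) for cytotoxicity (on this read-out lower numbers stand for stronger inhibition and higher numbers for weaker inhibition), compound 1 gives the highest of the three numbers, its nearest neighbour being compound 3 and the furthest compound 2. Compound 4 `O=C(/C=C/C(=O)N1C/C(=C\c2ccccc2)C(=O)/C(=C/c2ccccc2)C1)Nc1ccccc1` differs from compound 1 by phenyl in place of 2,6-dimethylphenyl on an amide-type nitrogen. Going by the values given here, no measured step changes the anilide part the same way; the only step on that part, a 2.1-fold higher number from compound 2 to compound 3 (0.33 log units; beyond the scatter), removes a substituent from the anilide ring and makes the number modestly higher. Compound 2 and compound 3 also carry nitro groups absent from compound 1, so the analogy is loose. A modest weakening, a 1.4-fold higher number from compound 1 to compound 4 (0.13 log units; within the scatter), is expected for compound 4, with an estimated value of 10000 nM and a range of 3500 nM to 30000 nM.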

Compound 4, half-maximal inhibitory concentration: 1100 nM
Compound 4: the middle estimate sits 9.1-fold (0.96 log units) above what was measured, outside the stated range (below it).
By their numbers in this assay, from the lowest: compound 2; then compounds 3 and 4 (each within the scatter of the next); then compound 1.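

In this assay, phenyl in place of 2,6-dimethylphenyl on the amide-type nitrogen gives a 6.7-fold lower number from compound 1 to compound 4 (0.83 log units; beyond the scatter), showing that the number at this position responds strongly to the two methyls. Going by these compounds alone, the earlier step on the anilide ring, a 2.1-fold higher number from compound 2 to compound 3 (0.33 log units; beyond the scatter), removed a chloro and went the other way, although only that pair carries nitro groups. No available evidence accounts for either step.

On these data alone, whether one methyl alone, or a methoxy group or an amine on the phenyl ring, would keep the lower number remains open. So does whether the same change would lower the number in the nitro-bearing series.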